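Swapping methoxy for cyano in a cytotoxicity test

This account rests on a few compounds, and the source may have more. Where it says the series, first, only, none or still open, it means among the compounds named here.

Compound 1 `N#CCCN(Cc1ccco1)S(=O)(=O)c1ccc(Cl)cc1`: > 205000 nM
Compound 2 `COc1ccc(S(=O)(=O)N(CCC#N)Cc2ccco2)cc1`: > 208000 nM

In an ADME assay on MDCK cells (Canis lupus familiaris) for cytotoxicity, read by MTT assay, with a stated time of 24 h (on this read-out lower numbers stand for higher toxicity in this test and higher numbers for lower toxicity in this test), compound 2 gives > 208000 nM, and this is a limit of the assay, not a number. The value of compound 1 is a limit too. Compound 3 `N#CCCN(Cc1ccco1)S(=O)(=O)c1ccc(C#N)cc1` keeps the rest of the structure of compound 2 and carries cyano in place of methoxy on an aromatic carbon.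

For the measured compounds named here, one measured step bears on this change, as it also alters the group on an aromatic carbon: a step that the two limits leave unreadable from compound 1 to compound 2. It gives no size to carry over, so no shift beyond the scatter is expected in this assay, and compound 3 will probably also return a limit. The expected step is a step that the limit leaves unreadable from compound 2 to compound 3. For compound 3 the estimated value is 211000 nM, with an expected range of 110000 nM to 230000 nM.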

Compound 3, half-maximal cytotoxic concentration: > 211000 nM
Compound 3: a limit, no number (the forecaster's own chance of this, stated with the estimate: 90%); the middle value sits exactly at the limit.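

In this assay, for the compounds shown here, compound 1, compound 2 and compound 3 each return a limit of the assay rather than a number, and no step between them can be read. The compounds shown leave open whether chloro, methoxy and cyano differ at all in this test.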